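A few compounds are considered here, and "the series" means these few. Any claim that something is new, unique, unknown or untested is made for them only; others in the source may bear on it.

In a functional assay on MCF7 cells (Homo sapiens) for antiproliferative activity, read by colorimetric assay and sulforhodamine B assay, with a stated time of 3 days (on this read-out lower numbers stand for stronger inhibition and higher numbers for weaker inhibition), compound 1 `Clc1ncnc2c1ncn2CC1COc2ccccc2S1` gives 10600 nM and compound 2 `Clc1ncnc2c1ncn2CC1CSc2ccccc2O1` gives 9240 nM, so compound 2 stands level with compound 1, within the scatter. Compound 3 `Nc1ncnc2c1ncn2CC1CSc2ccccc2O1` has amino in place of chloro on an aromatic carbon of the shared core (amino in place of chloro on an aromatic carbon). Among the compounds with values here, no measured pair shows this exchange, so the expectation is tentative. A moderate move to weaker inhibition in this assay is expected, with the estimated step being a 2.7-fold higher number from compound 2 to compound 3 (0.43 log units; beyond the scatter). Compound 3 is estimated at 25000 nM, with an expected range of 9000 nM to 70000 nM.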

Compound 3, half-maximal inhibitory concentration: > 30000 nM
Compound 3: a limit, no number; the forecaster's own chance of this, stated with the estimate: 20%; middle value at least 1.2-fold (0.07 log units) from the limit.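

In this assay, this pair is the only one that shows a single exchange at this aromatic carbon of the shared core, and amino in place of chloro gives an at least 3.2-fold higher number from compound 2 to compound 3 (0.51 log units; beyond the scatter). Compound 3 carries a limit and not a number: the limit of > 30000 nM in this assay, at which 1 of the 3 values shown sits.
The step therefore has a lower bound only, and its full size stays unread. Going by these compounds, whether methoxy or dimethylamino on this carbon would fall nearer chloro or amino stays open, as does the effect of the same exchange on the core of compound 1.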